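Aryl swap on the aromatic nitrogen: compound 2 to compound 3

The source may hold more compounds than are shown below. What is called first, only, known or untested is meant among the compounds shown, and "the series" means these compounds.

For the measured compounds named here, compound 2 `Oc1cc(C(F)(F)F)ccc1-c1nc(-c2ccccc2O)n(-c2cccc(Cl)c2)n1` gives the lowest of the two numbers so far in a functional assay on PC-12 cells (Rattus norvegicus) for cytotoxicity, read by MTT assay, with stated times of 2 h and 24 h, tested at 10 uM (a higher number here means a stronger effect of the compound at the concentration tested, a lower number a weaker effect), compound 2 reading 100%. Its nearest neighbour is compound 1 `Oc1cc(C(F)(F)F)ccc1-c1nc(-c2ccccc2O)n(-c2ccc(I)cc2)n1`, which in this assay gives 105%, and the step of a number 5 percentage points lower from compound 1 to compound 2 (within the scatter) lies within the scatter. Compound 3 `Cc1ccc(-n2nc(-c3ccc(C(F)(F)F)cc3O)nc2-c2ccccc2O)c(C)c1` differs from compound 2 by 2,4-dimethylphenyl in place of 3-chlorophenyl on an aromatic nitrogen. Going by the values given here, the only measured step touching this aryl group at the aromatic nitrogen is the one from compound 1 to compound 2, and it stayed within the scatter, so no step beyond the scatter is expected here. Compound 3 is expected to sit close to compound 2, a step of no change at the digits printed from compound 2 to compound 3 (within the scatter). The estimate for compound 3 is 100%, ranging from 85% to 112%.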

Compound 3, a percentage reported as activity, at one concentration (the size of the read-out at that concentration, not a potency): 106%
Beside the measured number, compound 3's estimate is 6 percentage points below it; measured number inside the range.
By their numbers in this assay, from the lowest: compounds 2, 1 and 3 (each within the scatter of the next).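

In this assay, 2,4-dimethylphenyl in place of 3-chlorophenyl gives a number 6 percentage points higher from compound 2 to compound 3 (within the scatter), and in place of 4-iodophenyl it gives a number 1 percentage points higher from compound 1 to compound 3 (within the scatter). An aryl group without halogen on the aromatic nitrogen therefore reads the same as the two halogen-bearing ones, and a change to two methyl groups separates nothing here. No data on hand explain this sameness.

Still open, as far as these compounds go, is whether an amine or a carboxylic acid on this phenyl ring, or cyclohexyl in place of the ring, would move the reading beyond the scatter.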